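Adding a Second Hydroxy to Compound 2

The compounds below may be only part of what the source reports. "The series", "measured", "known", "first", "only" and "open" are said of these compounds alone.

Going by the values given here, only two compounds built on this shared core have numbers so far in a functional assay on MDA-MB-231 cells (Homo sapiens) for inhibition, read by MTT assay, with a stated time of 48 h (a higher number here means a weaker inhibitor, a lower number a stronger inhibitor), for now. Compound 1 (`COc1cc(-c2cc(-c3cccc([N+](=O)[O-])c3)nc(-c3ccccc3)n2)cc(OC)c1OC`) gives 2440 nM and compound 2 (`COc1cc(-c2cc(-c3ccc(O)cc3)nc(-c3ccccc3)n2)cc(OC)c1OC`) gives 1600 nM in that test. Swapping 3-nitrophenyl for 4-hydroxyphenyl produced a 1.5-fold lower number from compound 1 to compound 2 (0.18 log units; within the scatter) and so compound 2 cannot be ranked against its only neighbour.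

Compound 3 (`COc1cc(-c2cc(-c3ccc(O)cc3O)nc(-c3ccccc3)n2)cc(OC)c1OC`) differs from compound 2 by one small edit: hydroxy in place of hydrogen on an aromatic carbon which is hydroxy in place of hydrogen on an aromatic carbon, turning 4-hydroxyphenyl into 2,4-dihydroxyphenyl. Among the compounds with values here, no measured step adds a hydroxy to a ring that already carries one, so the data offer no direct precedent. The nearest evidence is a 1.5-fold lower number from compound 1 to compound 2 (0.18 log units; within the scatter) and it involves a different swap on the same group. Within the data shown here, with only that step as a guide, no change beyond the scatter is expected in this assay in either direction. The estimated step is a 1.1-fold lower number from compound 2 to compound 3 (0.06 log units; within the scatter) and it should be read as a cautious expectation. For compound 3 the expected value is 1400 nM with an estimated range from 450 nM to 4000 nM in this test.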

Compound 3, half-maximal inhibitory concentration: 810 nM
Compound 3: the middle estimate sits 1.7-fold (0.24 log units) above what was measured; the range from low to high includes it.
By their numbers in this assay, from the lowest: compounds 3, 2 and 1 (each within the scatter of the next, the first and the last beyond it).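

In this assay, the second hydroxy, ortho to a large group and meta to the first hydroxy, gives a 2.0-fold lower number from compound 2 to compound 3 (0.30 log units; within the scatter) and so compound 3 cannot be ranked against compound 2: on this evidence, adding the group neither clearly helps nor clearly harms. Going by these compounds alone, the new information comes from the wider swap of 3-nitrophenyl for 2,4-dihydroxyphenyl, which gives a 3.0-fold lower number from compound 1 to compound 3 (0.48 log units; beyond the scatter) and is the first step at this position to lie beyond the scatter, though only modestly, whereas 4-hydroxyphenyl in compound 2 could not be separated from compound 1. Nothing available explains this difference between the groups.

Going by these compounds, it remains open whether a methoxy, an amine or a carboxylic acid at the same place on the ring would give a number clearly apart from that of compound 2. It is also unclear whether a lone hydroxy at that place, without the one already on the ring, would stand apart from compound 1 as compound 3 does.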